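The compounds below may be only part of what the source reports. "The series", "measured", "known", "first", "only" and "open" are said of these compounds alone.

Compound 1 `COc1ccc(-c2[nH]c3ccc(F)cc3c2C=O)cc1` gives 540 nM in a functional assay on MDA-MB-231 cells (Homo sapiens) for antiproliferative activity, with a stated time of 4 days; a lower number here means a stronger inhibitor, a higher number a weaker inhibitor.
Compound 2 `COc1ccc(-c2[nH]c3ccc(C)cc3c2C=O)cc1` gives 86 nM.
Compound 3 `CCCCCc1ccc2[nH]c(-c3ccc(OC)cc3)c(C=O)c2c1` gives 5.5 nM.

Compound 3 stands lowest of the three numbers, and both steps that lead to it lie beyond the scatter: a 98-fold lower number from compound 1 to compound 3 (1.99 log units; beyond the scatter) and a 16-fold lower number from compound 2 to compound 3 (1.19 log units; beyond the scatter). Between the other two, a 6.3-fold lower number from compound 1 to compound 2 (0.80 log units; beyond the scatter). Compound 3 is therefore the strongest inhibitor among the measured compounds.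

Compound 4 `CCCCCCc1ccc2[nH]c(-c3ccc(OC)cc3)c(C=O)c2c1` has not been measured. It differs from compound 3 in one place: methyl in place of hydrogen on a saturated chain carbon, five bonds along the chain from an aromatic carbon. The chain on the shared core grows by one carbon, from pentyl to hexyl. The measured step that bears most directly on this is a 16-fold lower number from compound 2 to compound 3 (1.19 log units; beyond the scatter), where butyl entered on the same chain carbon and the number fell sharply; a 98-fold lower number from compound 1 to compound 3 (1.99 log units; beyond the scatter) points the same way. Those steps each added several carbons at once, whereas the change to compound 4 adds a single one, so a smaller shift is expected, in the lowering direction, but possibly not beyond the scatter. The estimate for compound 4 is 4 nM, within a range of 1.5 nM to 12 nM, which means an expected step of a 1.4-fold lower number from compound 3 to compound 4 (0.14 log units; within the scatter).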

Compound 4, half-maximal inhibitory concentration: 7.4 nM
Compound 4: middle estimate off by 1.9-fold (0.27 log units), on the low side, and the stated range covers the measured number.
By their numbers in this assay, from the lowest: compounds 3 and 4 (each within the scatter of the next); then compound 2; then compound 1.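

In this assay, among the compounds shown here, extending the chain by one carbon, from pentyl to hexyl, gives a 1.3-fold higher number from compound 3 to compound 4 (0.13 log units; within the scatter) and so makes no readable difference at this place, which the earlier compounds could not show because their steps each changed the group by several atoms at once. The large separation from the smaller groups remains, with a 12-fold lower number from compound 2 to compound 4 (1.07 log units; beyond the scatter) and a 73-fold lower number from compound 1 to compound 4 (1.86 log units; beyond the scatter) both read for the hexyl chain, so in these compounds a longer chain at this place does not cost the advantage already seen with pentyl. No measured property of these compounds is available to explain this levelling between pentyl and hexyl.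

The compounds shown leave open where between methyl and pentyl most of the gain arises, since ethyl, propyl and butyl chains do not appear among them. They also leave open whether a longer chain such as octyl would hold this level or lose it, and how a chain carrying an amine or a carboxylic acid would compare at the same place.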